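A few compounds are considered here, and "the series" means these few. Any claim that something is new, unique, unknown or untested is made for them only; others in the source may bear on it.

Three amides of the shared core have been measured in an assay on LtK cells with ATP-sensitive inward rectifier potassium channel 11 (Homo sapiens) as the target; a higher number here means that more compound is needed for the effect, a lower number that less compound is needed. Compound 1 `CCC(C)C(=O)Nc1c(C(O)(C(F)(F)F)C(F)(F)F)ccc2ccccc12` gives 177000 nM. Compound 2 `CCC(CC)C(=O)Nc1c(C(O)(C(F)(F)F)C(F)(F)F)ccc2ccccc12` gives 4340 nM, and compound 3 `O=C(CC1CCCC1)Nc1c(C(O)(C(F)(F)F)C(F)(F)F)ccc2ccccc12` gives 81 nM. Compound 2 therefore stands second highest of the three numbers: the step of a 41-fold lower number from compound 1 to compound 2 (1.61 log units; beyond the scatter) places compound 1 above it, and the step of a 54-fold lower number from compound 2 to compound 3 (1.73 log units; beyond the scatter) places compound 3 below it. Compound 3 also stands far from compound 1, by a 2200-fold lower number from compound 1 to compound 3 (3.34 log units; beyond the scatter). Every change so far has been made at the carbonyl carbon, and each has moved this assay by a large amount.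

Compound 4 `O=C(Nc1c(C(O)(C(F)(F)F)C(F)(F)F)ccc2ccccc12)c1ccccc1Cl` has not been measured. Against compound 2 the change is 2-chlorophenyl in place of pentan-3-yl on a carbonyl carbon. For the measured compounds named here, the steps that bear on it are a 41-fold lower number from compound 1 to compound 2 (1.61 log units; beyond the scatter) and a 54-fold lower number from compound 2 to compound 3 (1.73 log units; beyond the scatter), both large and both in the same direction, the step to compound 3, which brings a ring, being the larger. Going by the values given here, no measured compound carries an aromatic group or a chlorine on the carbonyl carbon, so the size and even the direction of the step for compound 4 rest on these aliphatic steps alone. A lower number than that of compound 2 is expected, though short of the step to compound 3. In this assay compound 4 is estimated at 800 nM, range 120 nM to 6000 nM. The expected step is a 5.4-fold lower number from compound 2 to compound 4 (0.73 log units; beyond the scatter).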

Compound 4, half-maximal effective concentration: 2040 nM
Estimate against measurement, compound 4: 2.6-fold (0.41 log units) below, and the stated range covers the measured number.
By their numbers in this assay, from the lowest: compound 3; then compound 4; then compound 2; then compound 1.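

Within the series, 2-chlorophenyl is the first aromatic group on this carbonyl carbon, and in this assay it gives only a modest change against the branched pentan-3-yl, a 2.1-fold lower number from compound 2 to compound 4 (0.33 log units; beyond the scatter). A ring on the carbonyl carbon does not by itself give the low number of compound 3: compound 4 also carries a ring, yet the step is a 25-fold higher number from compound 3 to compound 4 (1.40 log units; beyond the scatter), so the kind of ring and how it is attached matter here, at least between these two compounds. Against the smaller sec-butyl, 2-chlorophenyl remains a large gain, an 87-fold lower number from compound 1 to compound 4 (1.94 log units; beyond the scatter), which places compound 4 in the middle of the series, with compound 3 still holding the lowest number.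

Still open, on these data alone, is how much of the step belongs to the chlorine and how much to the aromatic ring, which a plain phenyl would separate, and whether a benzyl group, with its methylene link like that of cyclopentylmethyl, would bring an aromatic ring closer to compound 3. No supporting data are available to explain any of these differences at this position.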